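The source may report more compounds than this note shows. Statements on the series, on what has been measured and on what is new or still open speak of the compounds shown alone.

Measured compounds:
- compound 1, `Cc1ccc(S(=O)(=O)N(CC(=O)NCc2ccc(Cl)cc2)c2cccnc2)cc1`, with < 1000 nM in an assay on CHO cells for displacement of a labelled ligand from prostaglandin E2 receptor EP1 subtype (Homo sapiens); a lower number here means a stronger inhibitor, a higher number a weaker inhibitor
- compound 2, `Cc1ccc(S(=O)(=O)N(CC(=O)NCc2ccc(Cl)cc2)c2ncccc2C)cc1`, with 794 nM in this assay

Compound 1 carries pyridin-3-yl on the sulfonamide nitrogen, and in this assay its value is a limit of the assay rather than a number, (the limit of < 1000 nM in this assay, at which 1 of the 2 values shown sits). Among the measured compounds shown here, compound 2 is the only compound here with a full number in this assay. The step that the limit leaves unreadable from compound 1 to compound 2 cannot be read in size or direction, since one end is a limit.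

Compound 3, `Cc1ccc(S(=O)(=O)N(CC(=O)NCc2ccc(Cl)cc2)c2ccc(C)nc2)cc1`, is not yet measured. It differs from compound 2 in one place: 6-methylpyridin-3-yl in place of 3-methylpyridin-2-yl on a sulfonamide nitrogen. For the measured compounds named here, no measured step runs between two full numbers, so the data give no guide to the size or direction of this change. Compound 3 is therefore expected to stay close to compound 2, with an estimated step of a 1.0-fold higher number from compound 2 to compound 3 (0.00 log units; within the scatter). Compound 3 is estimated at 800 nM in this assay, within a range from 250 nM to 2500 nM.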

Compound 3, inhibition constant: < 1000 nM
Compound 3 was reported as a limit (the forecaster's own chance of this, stated with the estimate: 25%); the middle value does not contradict the limit.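

In this assay, compound 3 gives < 1000 nM, a limit and not a number. Its steps from compound 1 and compound 2 therefore cannot be read: the limit of < 1000 nM in this assay, at which 2 of the 3 values shown sit. The compounds shown leave open whether 6-methylpyridin-3-yl in place of 3-methylpyridin-2-yl on the sulfonamide nitrogen changes the value at all.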